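The source may report more compounds than this note shows. Statements on the series, on what has been measured and on what is new or still open speak of the compounds shown alone.

Of the compounds shown here, three have so far been measured in a functional assay on A549 cells (Homo sapiens) for cytotoxicity, read by MTT assay, with a stated time of 72 h; a higher number here means a weaker inhibitor, a lower number a stronger inhibitor. Compound 1 `COc1cc2c(Oc3ccc(NC(=O)c4cn(-c5ccccc5)nn4)cc3F)ccnc2cc1OCCCN1CCCC1` gives 360 nM, compound 2 `COc1cc2c(Oc3ccc(NC(=O)c4cn(-c5ccccc5Cl)nn4)cc3F)ccnc2cc1OCCCN1CCCC1` gives 330 nM, and compound 3 `COc1cc2c(Oc3ccc(NC(=O)c4cn(-c5ccccc5)nn4)cc3F)ccnc2cc1OCCCN1CCCCC1` gives 130 nM, the lowest of the three numbers. Compound 4 `COc1cc2c(Oc3ccc(NC(=O)c4cn(-c5ccccc5F)nn4)cc3F)ccnc2cc1OCCCN1CCCCC1` is not yet measured; it differs from compound 3 by fluoro in place of hydrogen on an aromatic carbon. The measured step that bears on this change is a 1.1-fold lower number from compound 1 to compound 2 (0.04 log units; within the scatter), where a halogen likewise took the place of hydrogen on an aromatic carbon. The other step, a 2.8-fold lower number from compound 1 to compound 3 (0.44 log units; beyond the scatter), concerns a different part of the shared core and does not inform it. The step expected in this assay is therefore no change at the digits printed from compound 3 to compound 4 (within the scatter), none beyond the scatter. Compound 4 is estimated at 130 nM, with a range from 65 nM to 260 nM.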

Compound 4, half-maximal inhibitory concentration: 2770 nM
For compound 4 the middle estimate is 21-fold (1.33 log units) below the measured one; the measured number lies above the stated range.
By their numbers in this assay, from the lowest: compound 3; then compounds 2 and 1 (each within the scatter of the next); then compound 4.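

In this assay the step to the 2-fluorophenyl group is large, a 21-fold higher number from compound 3 to compound 4 (1.33 log units; beyond the scatter), so one fluoro on this aromatic carbon, ortho to a large group, can matter greatly when the chain ends in piperidin-1-yl. The chloro step, a 1.1-fold lower number from compound 1 to compound 2 (0.04 log units; within the scatter), showed nothing of the kind, but it involved another halogen and a chain ending in pyrrolidin-1-yl. Nothing available explains the size of the new step.

Open, as far as these compounds go, is whether 2-chlorophenyl on the piperidin-1-yl chain would give a similar step. So too is whether a methyl or methoxy group in place of this fluoro would.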